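The compounds below may be only part of what the source reports. "The series", "measured", "known", "first", "only" and "open" are said of these compounds alone.

Of the compounds shown here, three sharing one core have been measured so far. In a functional assay (aorta) with Rattus norvegicus as the target (a lower number here means that less compound is needed, a higher number that more compound is needed for the effect), compound 1 `COc1ccc(-c2nc(N=C(N)N)sc2-c2ccc(OC)cc2)cc1` gives 2 uM and compound 2 `CNC(=N)Nc1nc(-c2ccc(OC)cc2)c(-c2ccc(OC)cc2)s1` gives 1.2 uM as its value. These two differ by a 1.7-fold lower number from compound 1 to compound 2 (0.22 log units; within the scatter) and cannot be told apart. Compound 3 `COc1ccc(-c2nc(CNC(=O)NC(C)C)sc2-c2ccc(OC)cc2)cc1` gives 5.7 uM as its value and holds the highest number of the three, so more of it is needed for the effect.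

Among the compounds with values here, compound 4 `CCOC(=O)/C(C#N)=C/c1nc(-c2ccc(OC)cc2)c(-c2ccc(OC)cc2)s1` keeps both 4-methoxyphenyl groups but carries 2-cyano-2-(ethoxycarbonyl)ethenyl in place of ((isopropylcarbamoyl)amino)methyl on an aromatic carbon as its one change. The best guides are the two measured swaps that ended in compound 3, namely a 2.9-fold higher number from compound 1 to compound 3 (0.45 log units; beyond the scatter) and a 4.8-fold higher number from compound 2 to compound 3 (0.68 log units; beyond the scatter) at this same place. Both were modest, which suggests that exchanging one open chain for another here need not move the number far. Within the data shown here, still, no measured compound carries the entering group, so the direction stays open and the range must be wide.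

For compound 4 the expected step is a 1.1-fold lower number from compound 3 to compound 4 (0.06 log units; within the scatter) and no shift beyond the scatter is expected. Compound 4 is estimated at 5 uM in this assay with an expected range from 1.5 uM up to 17 uM around that estimate.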

Compound 4, concentration for half-maximal effect: > 100 uM
Compound 4 gave a limit, no number; the forecaster's own chance of this, stated with the estimate: 10%; middle value at least 20-fold (1.30 log units) from the limit.
By their numbers in this assay, from the lowest: compounds 2 and 1 (each within the scatter of the next); then compound 3. At a limit, above all of these: compound 4.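

Compound 4 gives no number in this assay, only a limit: the limit of > 100 uM in this assay, at which 1 of the 4 values shown sits.

Until now, exchanging one open chain for another on this aromatic carbon had produced only modest steps, but this exchange produces a large one, an at least 17-fold higher number from compound 3 to compound 4 (1.24 log units; beyond the scatter), and the gaps to the other two compounds are also large, an at least 50-fold higher number from compound 1 to compound 4 (1.69 log units; beyond the scatter) and an at least 83-fold higher number from compound 2 to compound 4 (1.92 log units; beyond the scatter). The position is therefore not indifferent to what it carries: the three earlier groups all give measured values, while 2-cyano-2-(ethoxycarbonyl)ethenyl, with 0 hydrogen-bond donors against the 2 of ((isopropylcarbamoyl)amino)methyl, does not reach a number.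

The entering group differs from the one it replaces in several ways at once, so these compounds cannot tell which of its parts, or which lost part of the old chain, accounts for the step. That question would need closer relatives of compound 4, such as a carboxylic acid in place of the ethyl ester, an ethenyl chain without the nitrile, or a simple aminomethyl group on the same carbon.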